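This account rests on a few compounds, and the source may have more. Where it says the series, first, only, none or still open, it means among the compounds named here.

Compound 3 `Cc1ccc2nc(Cl)c(/C=N/n3cc(-c4ccccc4)nc3N)cc2c1` gives 8790 nM in a functional assay on DLD-1 cells (Homo sapiens) for cytotoxicity, read by MTT assay, with a stated time of 48 h (a lower number here means a stronger inhibitor, a higher number a weaker inhibitor), the lowest of the two numbers shown, with compound 1 `Nc1nc(-c2ccccc2)cn1/N=C/c1cc2ccccc2nc1Cl` nearest at 16400 nM, a gap within the scatter. Compound 2 `COc1ccc(-c2cn(/N=C/c3cc4ccccc4nc3Cl)c(N)n2)cc1` reaches only a limit, > 50000 nM. Compound 4 `Cc1ccc2nc(Cl)c(/C=N/n3cc(-c4ccc(Cl)cc4)nc3N)cc2c1` differs from compound 3 by chloro in place of hydrogen on an aromatic carbon. Within the data shown here, two measured steps bear on this change. Putting a methoxy on the phenyl gave an at least 3.0-fold higher number from compound 1 to compound 2 (0.48 log units; beyond the scatter), while putting a methyl on the shared core gave a 1.9-fold lower number from compound 1 to compound 3 (0.27 log units; within the scatter). Because the chloro enters the same phenyl where the methoxy produced an at least 3.0-fold higher number from compound 1 to compound 2 (0.48 log units; beyond the scatter), compound 4 is expected to show a higher number, though its size is uncertain given (the limit of > 50000 nM in this assay, at which 1 of the 3 values shown sits). Compound 4 is therefore estimated at 22000 nM, between 7000 nM and 50000 nM, which means an expected step of a 2.5-fold higher number from compound 3 to compound 4 (0.40 log units; beyond the scatter).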

Compound 4, half-maximal inhibitory concentration: 38900 nM
Beside the measured number, compound 4's estimate is 1.8-fold (0.25 log units) below it, within the range that was stated.
By their numbers in this assay, from the lowest: compounds 3 and 1 (each within the scatter of the next); then compound 4. At a limit, above all of these: compound 2.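

The change from phenyl to 4-chlorophenyl gives a 4.4-fold higher number from compound 3 to compound 4 (0.65 log units; beyond the scatter). This makes chloro the second group on this phenyl, after the methoxy of compound 2, to move the number upward, and the pattern holds for both groups shown there, though on cores that differ by a methyl. It is also the first step on this phenyl with a full size, since compound 2 stays at a limit: the limit of > 50000 nM in this assay, at which 1 of the 4 values shown sits.

Still open, going by these compounds, is whether an amine or a carboxylic acid on this phenyl would also give a higher number. Whether chloro would have the same effect on the core of compound 1 is open too.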